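The source may report more compounds than this note shows. Statements on the series, on what has been measured and on what is new or still open speak of the compounds shown alone.

Compound 3 `ClCc1ccccc1Cn1cnc2nc(Cl)nc(Cl)c21` and compound 2 `ClCc1ccccc1Cn1cnc2ncnc(Cl)c21` share one core and differ in a single place: hydrogen in place of chloro on an aromatic carbon. In a functional assay on HOP-92 cells (Homo sapiens) for cytotoxicity, read by sulforhodamine B assay, with a stated time of 48 h (on this read-out lower numbers stand for higher toxicity in this test and higher numbers for lower toxicity in this test), compound 2 gives 51300 nM. For compound 3 this assay reports only a limit, > 100000 nM, not a number. Accordingly an at least 1.9-fold lower number from compound 3 to compound 2 (0.28 log units; that floor lies within the scatter) is known only as a floor, and that floor rests on (the limit of > 100000 nM in this assay, at which 1 of the 3 values shown sits).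

Compound 1 `ClCc1ccc(Cn2cnc3nc(Cl)nc(Cl)c32)cc1` holds the same atoms as compound 3, joined differently; the difference between the two cores is not broken down here. In this assay compound 1 stands as "not determined" (no result reported), so no number exists for it. Compound 4 `ClCc1ccc(Cn2cnc3ncnc(Cl)c32)cc1` is not yet measured and differs from compound 1 by the same change: hydrogen in place of chloro on an aromatic carbon.

No number exists for compound 1, and the measured step is known only as a floor. The expectation for compound 4 therefore leans on compound 2, whose value in this assay is 51300 nM. In this assay compound 4 is estimated at 60000 nM, and its value is expected to fall between 20000 nM and 150000 nM, with a real chance that only a limit is reported.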

Compound 4, concentration lethal to 50% of the cells: 5490 nM
Estimate against measurement, compound 4: 11-fold (1.04 log units) above; measured number outside the range, below it.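

Among the compounds shown here, compound 1 has no number in this assay, so compound 4 at 5490 nM yields no new step between these two compounds. The compounds shown leave open whether hydrogen in place of chloro changes the number on the core of compound 1, and on the core of compound 3 that change is known only as a floor. Nothing shown accounts for the value of compound 4.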